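The source may hold more compounds than are shown below. What is called first, only, known or untested is meant among the compounds shown, and "the series" means these compounds.

Three compounds have so far been run through an ADME assay on microsomes from liver (Homo sapiens) for metabolic stability, read by LC-MS, using NADPH, with stated times of 5 min and 30 min, tested at 1 uM; a lower number here means slower removal, a higher number faster removal of the compound. Compound 1, `Fc1ccc2c(c1CNc1ncc(Oc3ccccc3)c3nncn13)CCO2`, gives 18 mL.min-1.g-1. Compound 2, `Cc1ncccc1-c1cnc(NCc2c(F)ccc3c2CCO3)c2ncc(=O)[nH]c12`, gives 21 mL.min-1.g-1, and compound 3, `CN(C)Cc1ccc2c(c1)CN(c1cnc(NCc3c(F)ccc4c3CCO4)n3cnnc13)C2=O`, gives 19 mL.min-1.g-1. Compound 1 has the lowest of the three numbers, but its gaps to compound 3 and to compound 2 both fall within the usual scatter of this measurement, so the three cannot be told apart on these figures.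

The next compound, compound 4, `C[C@H]1CC(=O)N(c2cnc(NCc3c(F)ccc4c3CCO4)n3cnnc23)C1`, differs from compound 1 in one place: 4-methyl-2-oxopyrrolidin-1-yl in place of phenoxy on an aromatic carbon. The group that leaves and the group that enters are of the same size in heavy atoms and each carries one hydrogen-bond acceptor, though a six-membered aromatic ring of carbon only gives way to a five-membered non-aromatic ring with one hetero atom and a defined stereocentre.

Going by the values given here, no pair among the measured compounds shows this exchange, so its effect is untested here. Given that compounds 1, 2 and 3, which vary at this part of the shared core, all land close together, the step of a 1.2-fold lower number from compound 1 to compound 4 (0.08 log units; within the scatter) is expected to be small, with no direction that can be trusted beyond the scatter. Compound 4 is therefore estimated at 15 mL.min-1.g-1, within a range from 7 mL.min-1.g-1 to 35 mL.min-1.g-1.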

Compound 4, intrinsic clearance in microsomes: < 3 mL.min-1.g-1
Compound 4: only a limit was reported; the forecaster's own chance of this, stated with the estimate: 10%; at least 5.0-fold (0.69 log units) between middle value and limit.
By their numbers in this assay, from the lowest: compounds 1, 3 and 2 (each within the scatter of the next). At a limit, below all of these: compound 4.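

At this position, on an aromatic carbon of the shared core, swapping phenoxy for 4-methyl-2-oxopyrrolidin-1-yl gives in this assay an at least 6.0-fold lower number from compound 1 to compound 4 (0.77 log units; beyond the scatter), so a change in this one place can move the read-out beyond the scatter. The earlier compounds shown here offered no such reading, as no two of them differ in one place only, and their numbers all sit within the scatter of one another. Compound 4 is reported only as a limit, so the step marks the least that this change achieves and not its full size: the limit of < 3 mL.min-1.g-1 in this assay, at which 1 of the 4 values shown sits.

The exchange alters several things at once, replacing a six-membered aromatic ring of carbon only with a five-membered non-aromatic ring that brings a ring nitrogen, a carbonyl, a methyl group and a defined stereocentre, and the compounds shown cannot say which of these matters. A plain 2-oxopyrrolidin-1-yl group without the methyl, the opposite stereoisomer of the methyl compound, or a simple amine at this place would begin to separate those features.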